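The source may report more compounds than this note shows. Statements on the series, on what has been measured and on what is new or still open speak of the compounds shown alone.

Measured so far in a functional assay on SGC-7901 cells (Homo sapiens) for antiproliferative activity, read by MTT assay, with a stated time of 24 h; on this read-out lower numbers stand for stronger inhibition and higher numbers for weaker inhibition:
- compound 1 `O=c1[nH]cc(S(=O)(=O)Nc2ccccc2-c2cn(-c3ccccc3Cl)nn2)c(=O)[nH]1`: 6520 nM
- compound 2 `O=c1[nH]cc(S(=O)(=O)Nc2cccc(-c3cn(-c4cccc(F)c4)nn3)c2)c(=O)[nH]1`: > 20000 nM
- compound 3 `Cc1ccccc1-n1cc(-c2ccc(NS(=O)(=O)c3c[nH]c(=O)[nH]c3=O)cc2)nn1`: 13600 nM

Compound 3 gives the highest of the two numbers recorded in this assay. Its nearest neighbour is compound 1, whose value sits lower by a margin beyond the usual scatter. Compound 2 returns only a limit of the assay, (the limit of > 20000 nM in this assay, at which 1 of the 3 values shown sits), and so contributes no number to the comparison.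

Compound 4 `O=c1[nH]cc(S(=O)(=O)Nc2ccc(-c3cn(-c4cccc(Cl)c4)nn3)cc2)c(=O)[nH]1` is not yet measured. It differs from compound 3 in one place: 3-chlorophenyl in place of 2-methylphenyl on an aromatic nitrogen. The shared core and the attachment of the triazole to the sulfonamide-bearing ring are unchanged. For the measured compounds named here, no step between two measured compounds isolates this kind of exchange on the aromatic nitrogen, so the expectation rests on compound 3 alone. The step from compound 3 to compound 4 in this assay is expected to be a 1.1-fold higher number from compound 3 to compound 4 (0.04 log units; within the scatter), that is, no change beyond the scatter. Compound 4 is accordingly estimated at 15000 nM, with a plausible span from 6000 nM to 40000 nM.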

Compound 4, half-maximal inhibitory concentration: 2460 nM
Compound 4: middle estimate off by 6.1-fold (0.79 log units), on the high side, and the stated range ends above it.
By their numbers in this assay, from the lowest: compound 4; then compound 1; then compound 3. At a limit, above all of these: compound 2.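

In this assay, exchanging the group on the aromatic nitrogen gives a 5.5-fold lower number from compound 3 to compound 4 (0.74 log units; beyond the scatter), so with the shared core unchanged, this position is not indifferent to the group it carries. The step occurs with no change in the counted features of the two groups: heavy atoms, a six-membered aromatic ring of carbon only, and hydrogen-bond donors and acceptors. For the compounds shown here, the single step changes both the substituent and where it stands on the phenyl ring, so it cannot show which of the two accounts for the difference, and nothing measured here gives a cause for it.

On these data alone, how 3-methylphenyl or 2-chlorophenyl would read on this same core remains open, and either could help separate the two changes. Also open, as far as these compounds go, is whether a phenyl ring carrying an amine or a carboxylic acid would be tolerated here.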